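From fluoro to chloro on a floor of limits

This account rests on a few compounds, and the source may have more. Where it says the series, first, only, none or still open, it means among the compounds named here.

Measured in an ADME assay on HT-29 cells (Homo sapiens) for cytotoxicity, read by MTT assay, with a stated time of 72 h; a higher number here means a weaker inhibitor, a lower number a stronger inhibitor:
Compound 1 `COc1ccc(C2=C(c3cc(OC)c(OC)c(OC)c3)C(=O)C(OC(C)=O)C2)cc1` gives < 1 ug/mL as a limit
Compound 2 `COc1ccc(C2=C(c3cc(OC)c(OC)c(OC)c3)C(=O)C(OC(C)=O)C2)cc1F` gives < 1 ug/mL as a limit

Compound 2 stands at < 1 ug/mL as a limit of the assay, not as a number. All that is known is the limit of < 1 ug/mL in this assay, at which 2 of the 2 values shown sit, and no finer reading exists, so the two measured compounds cannot be put in any order.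

The next change is chloro in place of fluoro on an aromatic carbon and it leads to compound 3 `COc1ccc(C2=C(c3cc(OC)c(OC)c(OC)c3)C(=O)C(OC(C)=O)C2)cc1Cl` with chloro in place of fluoro on an aromatic carbon, ortho to a methoxy group and meta to a large group.

Among the measured compounds shown here, the only measured step that bears on this is a step that the two limits leave unreadable from compound 1 to compound 2 with fluoro in place of hydrogen on the same aromatic carbon. It offers neither a size nor a direction to carry over, so in this assay no step beyond the scatter is expected for compound 3. The expected step is a step that the limit leaves unreadable from compound 2 to compound 3 and it remains a rough estimate. For compound 3 the estimate is 0.5 ug/mL with an expected range from 0.05 ug/mL to 1 ug/mL and another report as a limit is likely.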

Compound 3, half-maximal inhibitory concentration: < 1 ug/mL
Compound 3 was reported as a limit (the forecaster's own chance of this, stated with the estimate: 85%); the middle value is on the limit's open side.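

In this assay compound 3 gives < 1 ug/mL, which is a limit and not a number. Among the compounds shown here, no step among compound 1, compound 2 and compound 3 can be read, so the three cannot be put in any order: the limit of < 1 ug/mL in this assay, at which 3 of the 3 values shown sit. The compounds shown leave open how strong each one actually is and whether they differ at all.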